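Swapping a chlorophenyl for a methylphenyl beside the ring nitrogen

This account rests on a few compounds, and the source may have more. Where it says the series, first, only, none or still open, it means among the compounds named here.

Compound 1 `Clc1ccc(-c2cc(-c3cccnc3)nc(-c3ccsc3)c2)o1`; compound 2 `Cc1cccc(-c2cc(-c3ccc(Cl)o3)cc(-c3ccsc3)n2)c1`; compound 3 `Clc1ccc(-c2cc(-c3ccsc3)nc(-c3ccccc3Cl)c2)o1`.

In a functional assay on HeLa cells (Homo sapiens) for cytotoxicity, in the presence of a further agent that is not named here (on this read-out higher numbers stand for weaker inhibition and lower numbers for stronger inhibition), compound 1 gives > 50000 nM, which is a limit of the assay and not a number. In this assay compound 2 gives 20300 nM. Compound 3 gives 8070 nM and stands lowest of the two numbers shown; the nearest step to it is a 2.5-fold lower number from compound 2 to compound 3 (0.40 log units; beyond the scatter). From compound 1 the steps are an at least 2.4-fold lower number from compound 1 to compound 2 (0.39 log units; beyond the scatter) and an at least 6.1-fold lower number from compound 1 to compound 3 (0.79 log units; beyond the scatter). Compound 4 `Cc1ccc(-c2cc(-c3ccc(Cl)o3)cc(-c3ccsc3)n2)cc1` differs from compound 3 by 4-methylphenyl in place of 2-chlorophenyl on an aromatic carbon. The step that bears on this is a 2.5-fold lower number from compound 2 to compound 3 (0.40 log units; beyond the scatter), which runs in the opposite direction, so a higher number is expected, roughly a 2.2-fold higher number from compound 3 to compound 4 (0.35 log units; beyond the scatter). Compound 4 is therefore estimated at 18000 nM, with a range from 7000 nM to 50000 nM.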

Compound 4, half-maximal inhibitory concentration: 16200 nM
The estimate for compound 4 lay 1.1-fold (0.05 log units) above the measured number, and the stated range covers the measured number.
By their numbers in this assay, from the lowest: compounds 3, 4 and 2 (each within the scatter of the next, the first and the last beyond it). At a limit, above all of these: compound 1.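

In this assay, a 1.3-fold lower number from compound 2 to compound 4 (0.10 log units; within the scatter) lies within the scatter, so these two methylphenyl groups are not told apart at this position. Against 2-chlorophenyl, a 2.0-fold higher number from compound 3 to compound 4 (0.30 log units; within the scatter) is also within the scatter, so the separation seen with 3-methylphenyl does not carry over to 4-methylphenyl. Both methylphenyl compounds still differ from the pyridin-3-yl compound, with an at least 3.0-fold lower number from compound 1 to compound 4 (0.48 log units; beyond the scatter), but that step is only a bound, since the value of compound 1 is a limit and not a number: the limit of > 50000 nM in this assay, at which 1 of the 4 values shown sits.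

The compounds shown leave open how an amine or a carboxylic acid on this phenyl ring would read out. They also leave open whether chlorine and methyl differ when placed at the same ring position.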